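Propyl to 4-fluorobenzyl on the triazole nitrogen of compound 1

The source may hold more compounds than are shown below. What is called first, only, known or untested is meant among the compounds shown, and "the series" means these compounds.

In a functional assay on RAW264.7 cells (Mus musculus) for inhibition, read by Griess assay, with stated times of 2 h and 24 h (on this read-out higher numbers stand for weaker inhibition and lower numbers for stronger inhibition), compound 1 `CCCn1cc(COc2cc(O)c3c(c2)O[C@H](c2ccc(OC)c(O)c2)CC3=O)nn1` gives 9670 nM. Its oxime counterpart compound 2 `CCCn1cc(COc2cc(O)c3c(c2)O[C@H](c2ccc(OC)c(O)c2)C/C3=N\O)nn1` gives 2340 nM, a number beyond the scatter below that of compound 1, while compound 3 `COc1ccc([C@@H]2C/C(=N\O)c3c(O)cc(OCc4cn(-c5ccccc5)nn4)cc3O2)cc1O` gives 6130 nM, which lies within the scatter of compound 1. Compound 4 `COc1ccc([C@@H]2CC(=O)c3c(O)cc(OCc4cn(Cc5ccc(F)cc5)nn4)cc3O2)cc1O` has not been measured; it differs from compound 1 by 4-fluorophenyl in place of ethyl on a saturated chain carbon bound to an aromatic nitrogen. Among the compounds with values here, no measured step shows this exact change. The nearest measured step, a 2.6-fold higher number from compound 2 to compound 3 (0.42 log units; beyond the scatter), concerns a different substituent on the same aromatic nitrogen within the oxime pair and gave a modest rise in the number. Taking that as the only guide, a step of similar direction and size, or none beyond the scatter, is expected in this assay for compound 4. The step expected for compound 4 is a 1.3-fold higher number from compound 1 to compound 4 (0.13 log units; within the scatter). Compound 4 is therefore estimated at 13000 nM, with a range from 5000 nM to 35000 nM.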

Compound 4, half-maximal inhibitory concentration: 15100 nM
Beside the measured number, compound 4's estimate is 1.2-fold (0.07 log units) below it; low and high end bracket the measured number.
By their numbers in this assay, from the lowest: compound 2; then compounds 3, 1 and 4 (each within the scatter of the next, the first and the last beyond it).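

In this assay, within the data shown here, the first step at this position on the ketone compounds is a 1.6-fold higher number from compound 1 to compound 4 (0.19 log units; within the scatter), so swapping propyl for 4-fluorobenzyl, which brings in a six-membered aromatic ring and a fluorine, leaves the number within the scatter. Among these compounds, the only earlier step on this nitrogen, a 2.6-fold higher number from compound 2 to compound 3 (0.42 log units; beyond the scatter), was read on the oxime pair and put phenyl in place of propyl on an aromatic nitrogen, so it could not show how the ketone compounds respond. The data shown offer no explanation for this result.

Going by these compounds, it remains open whether an amine, a carboxylic acid or a longer chain such as butyl on this nitrogen would move the number beyond the scatter. On these data alone, the oxime counterpart of compound 4 also remains open, including whether it would give a lower number than its ketone, as compound 2 does beside compound 1.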